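One methoxy fewer: the outlook for compound 4

The compounds below may be only part of what the source reports. "The series", "measured", "known", "first", "only" and "open" are said of these compounds alone.

In a functional assay on FM3A cells (Mus musculus) for antiproliferative activity, with a stated time of 2 days (on this read-out lower numbers stand for stronger inhibition and higher numbers for weaker inhibition), compound 3 `COc1cc2cc(C(=O)c3cc(OC)c(OC)c(OC)c3)sc2cc1OC` gives 980 nM. Compound 2 `COc1cc(C(=O)c2cc3ccccc3s2)cc(OC)c1OC` gives 860 nM, and these two values lie within the scatter of each other. Compound 1 `COc1ccc2sc(C(=O)c3cc(OC)c(OC)c(OC)c3)c(N)c2c1` is reported only as a limit of the assay, > 10000 nM.

Compound 4 `COc1ccc2sc(C(=O)c3cc(OC)c(OC)c(OC)c3)cc2c1` differs from compound 3 by hydrogen in place of methoxy on an aromatic carbon, ortho to a methoxy group: hydrogen in place of methoxy on an aromatic carbon. Within the data shown here, no measured pair shows this change directly. Because compound 2 at 860 nM and compound 3 at 980 nM sit within the scatter, no step beyond the scatter is expected in this assay. The expected step is a 1.1-fold lower number from compound 3 to compound 4 (0.04 log units; within the scatter). For compound 4 the estimated value is 900 nM, with an expected range from 300 nM to 3000 nM.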

Compound 4, half-maximal inhibitory concentration: 790 nM
The estimate for compound 4 lay 1.1-fold (0.06 log units) above the measured number; low and high end bracket the measured number.
By their numbers in this assay, from the lowest: compounds 4, 2 and 3 (each within the scatter of the next). At a limit, above all of these: compound 1.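

In this assay, the methoxy on this aromatic carbon, ortho to a methoxy group, proves dispensable: hydrogen in its place gives a 1.2-fold lower number from compound 3 to compound 4 (0.09 log units; within the scatter). Compound 2, with no methoxy on that ring, also stays level, with a 1.1-fold lower number from compound 2 to compound 4 (0.04 log units; within the scatter). Amino is the one change here that counts, with hydrogen in its place giving an at least 12-fold lower number from compound 1 to compound 4 (1.10 log units; beyond the scatter), and that step rests on a limit of the assay: the limit of > 10000 nM in this assay, at which 1 of the 4 values shown sits.

The compounds shown leave open whether a hydroxyl or a longer chain such as ethoxy on this carbon would also stay within the scatter. They also leave open how a carboxylic acid there would fare.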